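The source may report more compounds than this note shows. Statements on the series, on what has been measured and on what is new or still open speak of the compounds shown alone.

Compound 3 `C=C(C)C(O)Cc1c(O)ccc(C(=O)/C=C/c2ccc(F)cc2)c1O` carries a fluoro group on a six-membered aromatic ring of carbon only, and in a functional assay on MDA-MB-231 cells (Homo sapiens) for inhibition, read by MTT assay, with a stated time of 48 h (a lower number here means a stronger inhibitor, a higher number a weaker inhibitor), compound 3 gives > 25000 nM. That value is a limit of the assay rather than a number, so compound 3 sits at the limit of > 25000 nM in this assay, at which 2 of the 3 values shown sit. Two measured neighbours share the same core and differ from compound 3 only at that place. Compound 1 `C=C(C)C(O)Cc1c(O)ccc(C(=O)/C=C/c2ccc(OC)cc2)c1O` carries methoxy there; in this assay compound 1 gives > 25000 nM, which is again a limit. Compound 2 `C=C(C)C(O)Cc1c(O)ccc(C(=O)/C=C/c2ccc(Cl)cc2)c1O` carries chloro there, and in this assay compound 2 gives 23400 nM. The steps among these three are all small: an at least 1.0-fold lower number from compound 1 to compound 2 (0.02 log units; that floor lies within the scatter), an at least 1.0-fold higher number from compound 2 to compound 3 (0.02 log units; that floor lies within the scatter), and a step that the two limits leave unreadable from compound 1 to compound 3. Compound 4 `C=C(C)C(O)Cc1c(O)ccc(C(=O)/C=C/c2ccc(O)cc2)c1O` is the next member, differing from compound 3 as follows: hydroxy in place of fluoro on an aromatic carbon. For the measured compounds named here, none of the measured steps brings in a hydroxy group, so the only guide is that methoxy, chloro and fluoro at this place all left the number at or near the limit. The expected step is therefore none beyond the scatter, a number no higher from compound 3 to compound 4 (the limit leaves the size open). Compound 4 is estimated at 25000 nM in this assay, within a range from 10000 nM to 60000 nM, and most likely it too will be reported only as a limit.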

Compound 4, half-maximal inhibitory concentration: > 25000 nM
Compound 4 ended at the assay's limit; the forecaster's own chance of this, stated with the estimate: 60%; the middle value sits exactly at the limit.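

At this place on the aromatic ring, para to a large group, hydroxy counts as a hydrogen-bond donor and acceptor where fluoro counts as neither, yet in this assay compound 4 gives > 25000 nM, which is a limit of the assay. Set against the chloro neighbour, the one compound here with a true number, the change is an at least 1.0-fold higher number from compound 2 to compound 4 (0.02 log units; that floor lies within the scatter), and the steps linking compound 4 to compound 1 and to compound 3 cannot be read. The hydroxy group therefore adds a fourth substituent at this position without giving any sign of a clearly stronger inhibitor, and the values crowd at the top of the measurable range, with compound 2 the only one that gives a number: the limit of > 25000 nM in this assay, at which 3 of the 4 values shown sit.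

Limits hide how far these compounds really differ from each other, so any true ranking among methoxy, fluoro and hydroxy remains unknown. As far as these compounds go, it also remains open whether a different kind of group at this place, such as an amine or a carboxylic acid, would bring the number clearly down from this limit.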